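The source may report more compounds than this note shows. Statements on the series, on what has been measured and on what is new or still open speak of the compounds shown alone.

Working notes on the series.

Compound 1 `O=C(CCCCCCCn1cc(-c2cccnc2)nn1)Nc1ccccc1Cc1ccccc1` gives 30% in a functional assay on SH-SY5Y cells (Homo sapiens) for cytotoxicity, tested at 1 uM; on this read-out lower numbers stand for a stronger effect and higher numbers for a weaker effect at the one concentration tested. Compound 2 `O=C(CCCCCCCCn1cc(-c2cccnc2)nn1)Nc1ccccc1Cc1ccccc1` gives 13.1% in this assay. The difference between the core of compound 1 and the core of compound 2 is not broken down here; their two values simply show a gap beyond the scatter. Compound 3 `O=C(CCCCCCCn1cc(-c2cccnc2)nn1)Nc1ccccc1Oc1ccccc1` gives 17.7% in this assay; compound 2 and compound 3 lie within the scatter of each other.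

Among the measured compounds shown here, the one counted change in the set is phenoxy in place of benzyl on an aromatic carbon, which made a number 12.3 percentage points lower from compound 1 to compound 3 (beyond the scatter). The same change, (phenoxy in place of benzyl on an aromatic carbon), leads from compound 2 to compound 4 `O=C(CCCCCCCCn1cc(-c2cccnc2)nn1)Nc1ccccc1Oc1ccccc1`, which has yet to be measured in this assay. Both "place:" descriptions agree word for word, so this is the same change, occurring twice among the compounds shown.

For the measured compounds named here, for compound 4 a step of about a number 8.1 percentage points lower from compound 2 to compound 4 (within the scatter) is expected in this assay, resting on the single measured instance of this change, which gave a number 12.3 percentage points lower from compound 1 to compound 3 (beyond the scatter), and on compound 2 already standing at 13.1%, which leaves little room for the read-out to fall further. Compound 4 is therefore estimated at 5% in this assay, between 0% and 15%.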

Compound 4, a percentage reported as activity, at one concentration (the size of the read-out at that concentration, not a potency): 22.6%
Compound 4: the middle estimate sits 17.6 percentage points below what was measured; the measured number lies above the stated range.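

In this assay, phenoxy in place of benzyl on an aromatic carbon gave a number 9.5 percentage points higher from compound 2 to compound 4 (within the scatter), and this step does not match the one on the core of compound 1: the same change on two cores in this assay, a number 12.3 percentage points lower (beyond the scatter) from compound 1 to compound 3 and a number 9.5 percentage points higher (within the scatter) from compound 2 to compound 4, 21.8 percentage points apart, beyond the scatter of two such steps The change therefore cannot be carried from one of these cores to the other as a step of fixed size or direction. With a single pair on each core, this does not show what in the two cores separates the steps or how the change would behave on a further core, and on the core of compound 2 the step itself stays within the scatter.

The compounds shown leave open whether the split between the two steps holds for groups other than benzyl and phenoxy at this place on the ring, such as an amine or a carboxylic acid. On these data alone, it is also open which of the two steps, if either, a longer chain than that of compound 2 would follow.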